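Changing the Amide Amine of Compound 2

A few compounds are considered here, and "the series" means these few. Any claim that something is new, unique, unknown or untested is made for them only; others in the source may bear on it.

Compound 2 `O=C1C=CC(=O)C(c2cc(-c3ccc(C(=O)N4CCC(C(F)(F)F)CC4)s3)on2)=C1` carries a carbonyl bearing a 4-(trifluoromethyl)piperidin-1-yl group. In a functional assay on PC-3 cells (Homo sapiens) for cytotoxicity, read by XTT assay, with a stated time of 72 h (on this read-out lower numbers stand for stronger inhibition and higher numbers for weaker inhibition), compound 2 gives > 30000 nM, which is a limit of the assay rather than a number. Compound 1 `CCCN(C)C(=O)c1ccc(-c2cc(-c3cc(OC)ccc3OC)no2)s1` likewise reaches only the limit > 30000 nM in this assay. Compound 3 `CCN(CC)C(=O)c1ccc(-c2cc(-c3cc(OC)ccc3OC)no2)s1` also sits at the limit > 30000 nM. Between them stands a step that the two limits leave unreadable from compound 1 to compound 3. Compound 4 `CCN(CC)C(=O)c1ccc(-c2cc(C3=CC(=O)C=CC3=O)no2)s1` arises from compound 2 by diethylamino in place of 4-(trifluoromethyl)piperidin-1-yl on a carbonyl carbon. Among the compounds with values here, the only measured step that resembles this change, from compound 1 to compound 3, alters the same amine on the carbonyl and tells nothing because of the limit of > 30000 nM in this assay, at which 3 of the 3 values shown sit. No step beyond the scatter is therefore expected. The estimated change a step that the limit leaves unreadable from compound 2 to compound 4 reflects this. Compound 4 is expected to give 40000 nM in this assay, within a range from 15000 nM to 150000 nM.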

Compound 4, half-maximal inhibitory concentration: 8900 nM
For compound 4 the middle estimate is 4.5-fold (0.65 log units) above the measured one; measured number outside the range, below it.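

In this assay, the amine on this carbonyl carbon now makes a readable difference: diethylamino in place of 4-(trifluoromethyl)piperidin-1-yl gives an at least 3.3-fold lower number from compound 2 to compound 4 (0.52 log units; beyond the scatter). With 8900 nM, compound 4 supplies the first real number in this series, whereas the earlier step could not be read: the limit of > 30000 nM in this assay, at which 3 of the 4 values shown sit.

On these data alone, compound 2 has only a limit, so the full size of the step remains unknown. As far as these compounds go, it also remains open whether the gain comes from losing the trifluoromethyl group or the ring, and how an unsubstituted piperidin-1-yl, dimethylamino or morpholin-4-yl group would compare.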